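A few compounds are considered here, and "the series" means these few. Any claim that something is new, unique, unknown or untested is made for them only; others in the source may bear on it.

Measured compounds:
- Compound 1 `N#C/C(=C\c1c(F)c(F)c(F)c(F)c1F)C(=O)c1ccc[nH]1` — in a functional assay on MIA cells (Homo sapiens) for inhibition, read by MTT assay, with a stated time of 72 h (a higher number here means a weaker inhibitor of growth, a lower number a stronger inhibitor of growth), compound 1 gives 25000 nM
- Compound 2 `COc1ccc(CNC(=O)/C(C#N)=C/c2ccco2)cc1` — in this assay compound 2 gives 34000 nM

For the measured compounds named here, of these two numbers, compound 2 stands at the higher one, yet the gap to compound 1, its only neighbour, lies within the scatter of repeated measurements, so the two values show no difference that can be read as an order. Compound 3 `COc1ccc(CNC(=O)/C(C#N)=C/c2ccoc2)cc1` is not yet measured. It differs from compound 2 in one place: furan-3-yl in place of furan-2-yl on a double-bonded chain carbon bound to a double-bonded chain carbon. Going by the values given here, no measured pair in this set shows what such a change does, so there is no step to lean on. With both measured compounds weak and close to one another, the expectation is a step of no size beyond the scatter in this assay, in neither direction. For compound 3 the value in this assay is therefore estimated at 35000 nM, within a range from 12000 nM to 100000 nM, which means an expected step of a 1.0-fold higher number from compound 2 to compound 3 (0.01 log units; within the scatter).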

Compound 3, concentration for 50% growth inhibition: 8000 nM
For compound 3 the middle estimate is 4.4-fold (0.64 log units) above the measured one; the whole stated range lies above it.
By their numbers in this assay, from the lowest: compound 3; then compounds 1 and 2 (each within the scatter of the next).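

In this assay, for the compounds shown here, the exchange of furan-2-yl for furan-3-yl gives a 4.3-fold lower number from compound 2 to compound 3 (0.63 log units; beyond the scatter) and is the first step in this set that can be read in one place. The two groups have the same heavy atoms and the same counts of donors and acceptors, so on a double-bonded chain carbon bound to a double-bonded chain carbon, the way the furan ring is joined is enough to change the number beyond the scatter. No measurement shown here accounts for this step, and it stands without an explanation.

This single step cannot say whether a thiophen-3-yl or a pyridin-3-yl group at the same place would give a number like that of furan-3-yl. It also leaves open whether a methyl group on the furan-3-yl ring would keep the lower number.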